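The source may report more compounds than this note shows. Statements on the series, on what has been measured and on what is new or still open speak of the compounds shown alone.

Compound 1 `COc1ccc(-c2nnc(SC/C(=N/O)c3ccccc3)n2-c2ccccc2)cc1` is a triazole-based oxime ether. In a functional assay on the whole organism (strain albino) for inhibition, with Rattus norvegicus as the target, read by paw edema, with a stated time of 1 h, at a dose of 0.28 mmol/kg by the oral route (a higher number here means more inhibition at the dose given (going by the name of the read-out), a lower number less inhibition), compound 1 gives 58%. Compound 3 `O/N=C(/CSc1nnc(-c2ccccc2)n1-c1ccccc1)c1ccccc1` gives 60%, and compound 2 `CCn1c(SCC(=O)c2ccccc2)nnc1-c1ccc(OC)cc1` gives 53%, so compound 1 sits between the two, with all three numbers within the scatter of one another. Within the data shown here, the one step that can be followed, a number 2 percentage points higher from compound 1 to compound 3 (within the scatter), changes a substituent on an aromatic carbon and not the ring nitrogen.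

Compound 4 `C=CCn1c(SC/C(=N/O)c2ccccc2)nnc1-c1ccc(OC)cc1` differs from compound 1 at that nitrogen: allyl in place of phenyl on an aromatic nitrogen. Compound 2, which carries a small chain on the same nitrogen, gives a number within the scatter of compound 1, so no step beyond the scatter is expected. Compound 4 is therefore estimated at 55%, between 45% and 65%, a step of a number 3 percentage points lower from compound 1 to compound 4 (within the scatter) that is expected to stay within the scatter.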

Compound 4, a percentage reported as inhibition, in the whole organism at one dose (the size of the read-out at that dose, not a potency): 61%
For compound 4 the middle estimate is 6 percentage points below the measured one, and the stated range covers the measured number.
By their numbers in this assay, from the lowest: compounds 2, 1, 3 and 4 (each within the scatter of the next).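

The earlier step changed a substituent on an aromatic carbon, whereas this one changes the ring nitrogen itself, giving a number 3 percentage points higher from compound 1 to compound 4 (within the scatter) in this assay. At this nitrogen, a phenyl ring of 6 heavy atoms can therefore give way to an allyl chain of 3 heavy atoms with no step beyond the scatter. No measurement here gives a reason for this result.

On these data alone, it remains open whether a longer chain, an amine or a carboxylic acid on this nitrogen would also stay within the scatter. A single dose at a single time also leaves potency unknown.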